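A few compounds are considered here, and "the series" means these few. Any claim that something is new, unique, unknown or untested is made for them only; others in the source may bear on it.

Compound 1 `O=C1/C(=C/c2ccncc2)CN(S(=O)(=O)c2ccccc2)C/C1=C\c1ccccc1F`: 15900 nM
Compound 2 `O=C1/C(=C/c2ccncc2)CN(S(=O)(=O)c2ccccc2)C/C1=C\c1ccccc1C(F)(F)F`: 12300 nM

These numbers come from an ADME assay on L02 cells (Homo sapiens) for cytotoxicity, read by MTT assay, with a stated time of 24 h; a lower number here means a stronger inhibitor, a higher number a weaker inhibitor. Going by the values given here, only two compounds have been measured so far, and compound 2, at 12300 nM, lies within the usual scatter of compound 1. The next compound, compound 3 `N#Cc1ccc(S(=O)(=O)N2C/C(=C\c3ccncc3)C(=O)/C(=C/c3ccccc3C(F)(F)F)C2)cc1`, keeps all of compound 2 except that phenylsulfonyl becomes (4-cyanophenyl)sulfonyl, with cyano in place of hydrogen on an aromatic carbon.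

Among the compounds with values here, the single measured step, a 1.3-fold lower number from compound 1 to compound 2 (0.11 log units; within the scatter), swaps a different group at a different place, so it bears only indirectly on this change. Within the data shown here, it shows one swap that stayed within the scatter, and no measured pair carries a cyano group. No step beyond the scatter is therefore expected in this assay, and no direction can be favoured. The estimated step is a 1.0-fold lower number from compound 2 to compound 3 (0.01 log units; within the scatter). For compound 3 the expected value is 12000 nM, with an estimated range of 5000 nM to 28000 nM.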

Compound 3, half-maximal inhibitory concentration: 17600 nM
For compound 3 the middle estimate is 1.5-fold (0.17 log units) below the measured one; the measured number falls inside the stated range.
By their numbers in this assay, from the lowest: compounds 2, 1 and 3 (each within the scatter of the next).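

In this assay, the change from phenylsulfonyl to (4-cyanophenyl)sulfonyl gives a 1.4-fold higher number from compound 2 to compound 3 (0.16 log units; within the scatter) and so adds a second place in the molecule to the picture, since the earlier step concerned only the group swapped between compound 1 and compound 2. Cyano on this aromatic carbon therefore leaves the number indistinguishable from that of compound 2, so these three compounds show no measurable effect of either swap on the cell reading. No measurement is available that could explain this result.

As far as these compounds go, whether an amine or a carboxylic acid in the same place would carry the number beyond the scatter remains open. From the compounds shown here alone, it is also open whether cyano would give a similar step when paired with the fluoro group of compound 1.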